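Swapping one amine for another at the chain end

The source may hold more compounds than are shown below. What is called first, only, known or untested is meant among the compounds shown, and "the series" means these compounds.

Compound 1 `C[C@@H](CCCN1CCCCC1)Nc1ccnc2cc(Cl)ccc12` gives 150000 nM in an assay for binding affinity, read by spectrophotometry; a lower number here means a stronger inhibitor, a higher number a weaker inhibitor.
Compound 2 `C[C@@H](CCCN(C)C)Nc1ccnc2cc(Cl)ccc12` gives 150000 nM in this assay.

Compound 2 stands level with compound 1 on these numbers, within the scatter. Compound 3 `C[C@@H](CCCNC(C)(C)C)Nc1ccnc2cc(Cl)ccc12` differs from compound 2 by (tert-butyl)amino in place of dimethylamino on a saturated chain carbon, four bonds along the chain from a nitrogen on an aromatic ring. For the measured compounds named here, the one measured step that bears on this change, no change at the digits printed from compound 1 to compound 2 (within the scatter), also swapped one amine for another at the same place on the chain and left the number unchanged within the scatter. Compound 3 is therefore expected to show a step of no change at the digits printed from compound 2 to compound 3 (within the scatter) of no size beyond the scatter. The estimate for compound 3 is 150000 nM, expected between 75000 nM and 300000 nM.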

Compound 3, half-maximal inhibitory concentration: 150000 nM
The estimate for compound 3 equals the measured number at the digits printed, and the stated range covers the measured number.
By their numbers in this assay, from the lowest: compounds 1, 2 and 3 (each within the scatter of the next).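

In this assay the (tert-butyl)amino group gives no change at the digits printed from compound 2 to compound 3 (within the scatter) and also no change at the digits printed from compound 1 to compound 3 (within the scatter) at this place on the chain. For the compounds shown here, this is the first amine of the three to carry a hydrogen-bond donor, and compared with dimethylamino it has more heavy atoms, yet neither difference shifts the number. Nothing measured here explains why the three amines read alike. Still open, from the compounds shown here alone, is whether a group of another kind at the chain end, such as a carboxylic acid or a hydroxyl, would move the number. Going by these compounds, a longer chain is equally open.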